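Trimming the ring nitrogen substituent: a step to plain hydrogen

The compounds below may be only part of what the source reports. "The series", "measured", "known", "first", "only" and "open" are said of these compounds alone.

Of the compounds shown here, three have been tested in a functional assay on HepG2 cells (Homo sapiens) for cytotoxicity, read by sulforhodamine B assay, with a stated time of 48 h; on this read-out higher numbers stand for weaker inhibition and lower numbers for stronger inhibition. Compound 1 `C/C(=N\NC(=O)c1sc(N)c(C#N)c1N)c1ccc(NS(=O)(=O)c2ccc(C)cc2)cc1` gives 21800 nM. Compound 2 `Cc1ccc(S(=O)(=O)Nc2ccc(-c3cc(-c4ccc([N+](=O)[O-])cc4)n(C(N)=S)n3)cc2)cc1` is reported as "not active" (no number reported), with no number attached. Compound 3 `Cc1ccc(S(=O)(=O)Nc2ccc(-c3cc(-c4ccc([N+](=O)[O-])cc4)n(C(=S)NN)n3)cc2)cc1` gives 45300 nM, the highest of the two numbers available, standing beyond the scatter from compound 1 as its nearest neighbour, which means compound 3 is the weaker inhibitor of the two that carry a number.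

Compound 4 `Cc1ccc(S(=O)(=O)Nc2ccc(-c3cc(-c4ccc([N+](=O)[O-])cc4)[nH]n3)cc2)cc1` has not yet been measured. It differs from compound 3 in one place: a hydrogen atom in place of a group of 4 heavy atoms (1 carbon, 2 nitrogen, 1 sulfur; no ring), on an aromatic nitrogen, that is, a hydrogen atom in place of a group of 4 heavy atoms, on an aromatic nitrogen of the five-membered aromatic ring with 2 nitrogen. Within the data shown here, no pair of measured compounds shows this kind of change, so the direction is open; the step from compound 3 to compound 4 is expected to be modest and, if anything, toward weaker inhibition, a 1.3-fold higher number from compound 3 to compound 4 (0.12 log units; within the scatter). In this assay compound 4 is therefore estimated at 60000 nM, within a range of 20000 nM to 180000 nM.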

Compound 4, half-maximal inhibitory concentration: 44800 nM
Estimate against measurement, compound 4: 1.3-fold (0.13 log units) above; low and high end bracket the measured number.
By their numbers in this assay, from the lowest: compound 1; then compounds 4 and 3 (each within the scatter of the next).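

In this assay, putting a hydrogen atom on the aromatic nitrogen in place of the group of 4 heavy atoms gives a 1.0-fold lower number from compound 3 to compound 4 (0.00 log units; within the scatter) and so leaves no readable difference between the two compounds. Among these compounds, this is the first direct look at this position: in this pair, the whole group can be removed without moving the number beyond the usual scatter, so the plain ring nitrogen holds the same level of weak cytotoxicity. Nothing available explains why the group makes no readable difference here.

Compound 2 has no number, so its steps to compound 3 and compound 4 cannot be read. Going by these compounds, what a methyl group, an acetyl group or a longer chain on this nitrogen would do remains open, as does whether any such group could bring the number down.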